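The compounds below may be only part of what the source reports. "The series", "measured", "known", "first", "only" and "open" are said of these compounds alone.

Working notes on the series. Of the compounds shown here, two have so far been measured in a physicochemical assay for acid dissociation. Compound 1 `COc1ccc(-c2ccc3c(NCCCNCc4cccc(OC)c4O)ccnc3c2)cc1` gives 9.47 in this assay. Compound 2 `COc1ccc(F)cc1CNCCCNc1ccnc2cc(C3CCCCC3)ccc12` gives 9.47 in this assay. For the measured compounds named here, compound 1 therefore stands level with compound 2 at the digits reported, the two values lying within the scatter of each other; the two structures differ in more than one place, so no single step between them is recorded.

Compound 3 `COc1cccc(CNCCCNc2ccnc3cc(-c4ccc(C(C)(C)C)cc4)ccc23)c1O` has not yet been measured. Relative to compound 1 it carries tert-butyl in place of methoxy on an aromatic carbon; cut one bond further out, the same exchange reads as 4-methoxyphenyl to 4-(tert-butyl)phenyl, with the rest of the shared core unchanged. Going by the values given here, no measured step bears on this exchange, so the expectation rests on the two measured values and on the place of the change, on an aromatic carbon of a six-membered aromatic ring of carbon only, para to a large group. The step from compound 1 to compound 3 in this assay is expected to be small, no change at the digits printed from compound 1 to compound 3 (within the scatter), with no direction beyond the scatter. Compound 3 is accordingly expected to give about 9.47 in this assay, in a range of 9.1 to 9.85.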

Compound 3, acid dissociation constant: 9.47
Compound 3: the middle estimate sits on the measured number at the digits printed; the measured number falls inside the stated range.
By their numbers in this assay, from the lowest: compounds 1, 2 and 3 (each within the scatter of the next).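

In this assay, the exchange of methoxy for tert-butyl on an aromatic carbon, para to a large group, reads no change at the digits printed from compound 1 to compound 3 (within the scatter), and this is the only step shown that isolates one place in the series. Compounds 1 and 2 stood level while differing in more than one place, whereas this single exchange shows that the read-out stays within the scatter at this position when an oxygen-bearing group with one hydrogen-bond acceptor gives way to an all-carbon group with none and more heavy atoms. Nothing available speaks to the reason for this result.

On these data alone, it remains open whether the same reading would hold at this position for a group of another kind, such as an amine or a carboxylic acid. Also open, as far as these compounds go, is whether a single exchange elsewhere on the shared core, such as a longer chain in place of the linking chain, would read the same way.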